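The compounds below may be only part of what the source reports. "The series", "measured", "known", "first", "only" and "open" are said of these compounds alone.

In an assay on isolated protein for inhibition of Alpha glucosidase (Homo sapiens), with stated times of 5 min and 15 min, tested at 50 uM (a lower number here means less inhibition, a higher number more inhibition at the concentration tested (going by the name of the read-out)), compound 2 `O=C1/C(=C/c2ccccc2)CCC/C1=C\c1ccccc1Cl` gives 43%, the larger of the two numbers recorded so far, while compound 1 `O=C1/C(=C/c2ccccc2)CCC/C1=C\c1ccc(F)c(F)c1` gives 37.8%, a gap that lies within the usual scatter and so separates the two only nominally. Compound 3 `O=C1/C(=C/c2ccccc2)CCC/C1=C\c1cccc(F)c1` has not been measured in this assay. It differs from compound 2 by 3-fluorophenyl in place of 2-chlorophenyl on a double-bonded chain carbon bound to a double-bonded ring carbon. Within the data shown here, no step between measured compounds mirrors this change, and the expected shift in this assay, a number 5 percentage points lower from compound 2 to compound 3 (within the scatter), is a small downward one that stays within the scatter. Compound 3 is estimated at 38%, with a range from 25% to 52%.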

Compound 3, a percentage reported as inhibition, at one concentration (the size of the read-out at that concentration, not a potency): 39.8%
For compound 3 the middle estimate is 1.8 percentage points below the measured one; measured number inside the range.
By their numbers in this assay, from the lowest: compounds 1, 3 and 2 (each within the scatter of the next).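

In this assay, 3-fluorophenyl in place of 2-chlorophenyl on a double-bonded chain carbon bound to a double-bonded ring carbon gives a number 3.2 percentage points lower from compound 2 to compound 3 (within the scatter) and hydrogen in place of fluoro on an aromatic carbon gives a number 2 percentage points higher from compound 1 to compound 3 (within the scatter). Both steps lie within the scatter, so at this position neither change separates the compounds, whichever halogen the aromatic ring carries. Nothing measured here offers an explanation for this. From the compounds shown here alone, whether an amine, a carboxylic acid or a methoxy group on this aromatic ring would move the number beyond the scatter remains open. So does the result of changing the other phenyl group.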